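Methyl to methoxy on the aryl ring: cytotoxicity notes

The compounds below may be only part of what the source reports. "The series", "measured", "known", "first", "only" and "open" are said of these compounds alone.

Measured compounds:
Compound 1, `COc1ccc(NC(=O)c2c(NO)cc(-c3ccccc3)oc2=O)cc1`, gives in an ADME assay on Huh-7 cells (Homo sapiens) for cytotoxicity, read by a luciferase reporter and WST assay, with a stated time of 3 days (a higher number here means that more compound is tolerated, a lower number that less compound is tolerated), a value of > 20000 nM, which is a limit of the assay and not a number.
Compound 2, `Cc1ccc(NC(=O)c2c(NO)cc(-c3ccccc3)oc2=O)cc1`, gives in this assay a value of > 20000 nM, again a limit.
Compound 3, `Cc1ccc(-c2cc(NO)c(C(=O)NCCO)c(=O)o2)cc1`, gives in this assay a value of > 20000 nM, also a limit.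

Among the measured compounds shown here, the one structural change that can be compared across the series is methoxy in place of methyl on an aromatic carbon. The step that the two limits leave unreadable from compound 2 to compound 1 cannot be read in size, because both compounds sit at the limit of > 20000 nM in this assay, at which 3 of the 3 values shown sit. Nothing more about the size of this change can be drawn from the pair.

Compound 3 carries a different core from compound 2; the difference between the two cores is not broken down here. Compound 4, `COc1ccc(-c2cc(NO)c(C(=O)NCCO)c(=O)o2)cc1`, is not yet measured and differs from compound 3 by methoxy in place of methyl on an aromatic carbon, the same change that separates compound 2 from compound 1.

For compound 4 the step that the limit leaves unreadable from compound 3 to compound 4 is expected to be small, resting on the step that the two limits leave unreadable from compound 2 to compound 1 and on the fact that compound 3 itself stands at > 20000 nM. The most likely outcome for compound 4 is therefore again a limit rather than a number; the estimate for compound 4 in this assay is 25000 nM, with a range from 10000 nM to 60000 nM.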

Compound 4, half-maximal cytotoxic concentration: > 20000 nM
Compound 4: only a limit was reported; the forecaster's own chance of this, stated with the estimate: 85%; the middle value is on the limit's open side.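

Compound 4 gives > 20000 nM in this assay as a limit and not a number. No new step can be read from compound 3 and compound 4, whose change of methyl to methoxy stays unreadable in size: the limit of > 20000 nM in this assay, at which 4 of the 4 values shown sit.

In this assay the compounds shown leave open at what concentration any of the four becomes cytotoxic, and how large the change from methyl to methoxy is.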